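A smaller pyridinyl amide in the cytotoxicity test

A few compounds are considered here, and "the series" means these few. Any claim that something is new, unique, unknown or untested is made for them only; others in the source may bear on it.

Three compounds built on a shared core were examined in an ADME assay on MT4 cells (Homo sapiens) for cytotoxicity, read by MTT assay; on this read-out higher numbers stand for lower toxicity in this test and lower numbers for higher toxicity in this test. Compound 1 `Cc1cnc(NC(=O)CSc2nncnc2-c2ccccc2Cl)c(Br)c1` gives 144000 nM in this assay, the second highest of the three numbers. Compound 3 `Cc1ccc(NC(=O)CSc2nncnc2-c2cccc3ccccc23)c([N+](=O)[O-])c1` gives 147000 nM, a number within the scatter of that of compound 1. Compound 2 `O=C(CSc1nncnc1-c1ccccc1Cl)N1CCCc2ccccc21` gives 35000 nM, which lies beyond the scatter below the number of compound 1. Among the measured compounds shown here, no pair of measured compounds differs in one place only, so the size of a single change cannot be read from these numbers.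

Compound 4 `O=C(CSc1nncnc1-c1ccccc1Cl)Nc1ccccn1` has not yet been measured in this assay. It differs from compound 1 in one place: pyridin-2-yl in place of 3-bromo-5-methylpyridin-2-yl on an amide-type nitrogen. Because compound 1 gives 144000 nM and compound 3 gives 147000 nM in this assay, with only compound 2 falling away, the expected step here is none beyond the scatter, or a small one in either direction. Compound 4 is therefore expected to give about 150000 nM in this assay, within a range from 60000 nM to 350000 nM. The estimated change is a 1.0-fold higher number from compound 1 to compound 4 (0.02 log units; within the scatter).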

Compound 4, half-maximal cytotoxic concentration: 172000 nM
Compound 4: the middle estimate sits 1.1-fold (0.06 log units) below what was measured, within the range that was stated.
By their numbers in this assay, from the lowest: compound 2; then compounds 1, 3 and 4 (each within the scatter of the next).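

Among the compounds shown here, this is the first single-place step available at this position: in this assay, pyridin-2-yl in place of 3-bromo-5-methylpyridin-2-yl on an amide-type nitrogen gives a 1.2-fold higher number from compound 1 to compound 4 (0.08 log units; within the scatter), a step that lies within the scatter. The bromine and the methyl of the group that leaves are therefore not needed for the read-out to stay in this range, at least with the rest of compound 1 held fixed. The earlier compounds shown here could not show this, since no two of them differed in one place only.

As far as these compounds go, whether a methylamino group or a carboxylic acid on the pyridin-2-yl ring, or a longer chain in its place on the amide-type nitrogen, would also stay within the scatter remains open. The compounds shown also offer no measurement that explains the size of this step.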